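Chloro for Bromo on the Pendant Phenyl Ring

A few compounds are considered here, and "the series" means these few. Any claim that something is new, unique, unknown or untested is made for them only; others in the source may bear on it.

Going by the values given here, compound 2 `O=C1/C(=C\c2cccc(Br)c2)c2ccccc2N1c1c(Cl)cccc1Cl` gives the lowest of the two numbers measured so far in a functional assay on KB cells (Homo sapiens) for cytotoxicity, read by MTT assay, with a stated time of 72 h (on this read-out lower numbers stand for an effect already at smaller amounts and higher numbers for an effect only at larger amounts of compound), namely 2 ug/mL. Its nearest neighbour, compound 1 `O=C1/C(=C\c2ccc(F)cc2)c2ccccc2N1c1c(Cl)cccc1Cl`, gives 5 ug/mL. Compound 3 `O=C1/C(=C\c2cccc(Cl)c2)c2ccccc2N1c1c(Cl)cccc1Cl` differs from compound 2 by chloro in place of bromo on an aromatic carbon. Among the compounds with values here, the only measured step, a 2.5-fold lower number from compound 1 to compound 2 (0.40 log units; beyond the scatter), alters both the substituent and its placement on the ring, so it bears only loosely on a plain chloro-for-bromo swap, and no step beyond the scatter is expected. Compound 3 is therefore estimated at 2 ug/mL, between 1 ug/mL and 5 ug/mL, which is expected to be no change at the digits printed from compound 2 to compound 3 (within the scatter).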

Compound 3, concentration for half-maximal effect: 2 ug/mL
For compound 3 middle estimate and measured number coincide at the digits printed, and the stated range covers the measured number.
By their numbers in this assay, from the lowest: compounds 2 and 3 (each within the scatter of the next); then compound 1.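

In this assay the swap gives no change at the digits printed from compound 2 to compound 3 (within the scatter) at this aromatic carbon, meta to a large group, so chloro and bromo cannot be told apart here. The 3-chlorophenyl group in place of 4-fluorophenyl gives a 2.5-fold lower number from compound 1 to compound 3 (0.40 log units; beyond the scatter) as well, so a second halogen at this position repeats the earlier step. Nothing available offers a reason for either result. Still open, from the compounds shown here alone, is whether this position responds to anything other than a halogen, such as an amine or a carboxylic acid. Also open, going by these compounds, is how much of the step from 4-fluorophenyl comes from placement and how much from the halogen itself.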